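The source may hold more compounds than are shown below. What is called first, only, known or untested is meant among the compounds shown, and "the series" means these compounds.

Series notes. Compound 2 `Cc1ccc(-c2c3ccc4ccccc4c3nc3c2c(C)nc2c4ccccc4ccc32)cc1` in a functional assay on HCT-116 cells (Homo sapiens) for cytotoxicity, read by MTT assay, with a stated time of 48 h (on this read-out higher numbers stand for weaker inhibition and lower numbers for stronger inhibition), gives 67000 nM; of the two numbers shown it has the higher one, with compound 1 `Cc1nc2c3ccccc3ccc2c2nc3c(ccc4ccccc43)c(-c3ccccc3Cl)c12` at 48200 nM nearest, a 1.4-fold higher number from compound 1 to compound 2 (0.14 log units; within the scatter). Compound 3 `Cc1nc2c3ccccc3ccc2c2nc3c(ccc4ccccc43)c(C)c12` in this assay gives only a limit, > 80000 nM. Compound 4 `Cc1nc2c3ccccc3ccc2c2nc3c(ccc4ccccc43)c(-c3ccccc3)c12` is not yet measured; it differs from compound 2 by hydrogen in place of methyl on an aromatic carbon. For the measured compounds named here, no measured step removes a methyl from an aryl group; the nearest are the aryl swaps a 1.4-fold higher number from compound 1 to compound 2 (0.14 log units; within the scatter) and an at least 1.1-fold higher number from compound 2 to compound 3 (0.07 log units; that floor lies within the scatter), both small, with the limit of > 80000 nM in this assay, at which 1 of the 3 values shown sits, capping the series. The change is therefore expected to move this assay little, a 1.2-fold lower number from compound 2 to compound 4 (0.09 log units; within the scatter). Compound 4 is estimated at 55000 nM, between 25000 nM and 120000 nM.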

Compound 4, half-maximal inhibitory concentration: > 80000 nM
Compound 4: no number, only a limit; the forecaster's own chance of this, stated with the estimate: 35%; middle value at least 1.4-fold (0.16 log units) away from the limit.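

In this assay compound 4 gives only a limit, > 80000 nM. Taking the methyl off the aryl group, 4-methylphenyl to phenyl, reads only as an at least 1.1-fold higher number from compound 2 to compound 4 (0.07 log units; that floor lies within the scatter), and taking the chloro off 2-chlorophenyl reads only as an at least 1.6-fold higher number from compound 1 to compound 4 (0.22 log units; that floor lies within the scatter), so neither substituent is shown to matter. The step linking compound 3 and compound 4 cannot be read, and the series now rests partly on a shared limit: the limit of > 80000 nM in this assay, at which 2 of the 4 values shown sit.

No step shown lies beyond the scatter. From the compounds shown here alone, what an amine or a carboxylic acid on the phenyl group would do in this assay stays open.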